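Replacing methylsulfanyl with 2-fluorophenyl on the shared core

A few compounds are considered here, and "the series" means these few. Any claim that something is new, unique, unknown or untested is made for them only; others in the source may bear on it.

Compound 3 `CSc1cnc(C(=O)CCCCCCc2ccccc2)o1` stands at the edge of what the measurements show. In an assay on HEK-293T cells for inhibition of diacylglycerol lipase-alpha (Homo sapiens), read by colorimetric assay (a higher number here means a weaker inhibitor, a lower number a stronger inhibitor), compound 3 gives > 10000 nM, which is a limit of the assay and not a number. Compound 1 `O=C(CCCCCCc1ccccc1)c1ncc(C(=O)C(F)(F)F)o1` gives 1820 nM in this assay. Compound 2 `COc1cnc(C(=O)CCCCCCc2ccccc2)o1` gives > 10000 nM, again a limit. The step of an at least 5.4-fold higher number from compound 1 to compound 2 (0.73 log units; beyond the scatter) and the step of an at least 5.4-fold higher number from compound 1 to compound 3 (0.73 log units; beyond the scatter) both point the same way, while the step that the two limits leave unreadable from compound 2 to compound 3 cannot be read, since both of its ends sit at the limit of > 10000 nM in this assay, at which 2 of the 3 values shown sit.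

Compound 4 `O=C(CCCCCCc1ccccc1)c1ncc(-c2ccccc2F)o1` differs from compound 3 by 2-fluorophenyl in place of methylsulfanyl on an aromatic carbon. Within the data shown here, no measured step involves a 2-fluorophenyl, so the two readable steps bear on this change only loosely: they show that small groups at this place of the core leave activity at the limit, whereas the larger (trifluoromethyl)carbonyl of compound 1 gives a number. A group as large as 2-fluorophenyl is therefore expected to move away from the limit, the step of an at least 3.3-fold lower number from compound 3 to compound 4 (0.52 log units; beyond the scatter) being the expected change. For compound 4 the estimate is 3000 nM, within 500 nM to 20000 nM.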

Compound 4, half-maximal inhibitory concentration: > 10000 nM
Compound 4 gave a limit, no number; the forecaster's own chance of this, stated with the estimate: 40%; at least 3.3-fold (0.52 log units) between middle value and limit.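

In this assay compound 4 gives > 10000 nM, which is a limit of the assay and not a number. A large group at this place is therefore not enough to give a number: 2-fluorophenyl, with its six-membered aromatic ring of carbon only, stays at the limit with methoxy and methylsulfanyl, and only (trifluoromethyl)carbonyl stands apart, with an at least 5.4-fold higher number from compound 1 to compound 4 (0.73 log units; beyond the scatter). The steps among compound 2, compound 3 and compound 4 cannot be read, as all three sit at one limit: (the limit of > 10000 nM in this assay, at which 3 of the 4 values shown sit).

Still open, from the compounds shown here alone, is whether another carbonyl group at this place, such as acetyl or an amide, also gives a number, or whether a nitrile does. Also open, going by these compounds, is how far compound 2, compound 3 and compound 4 differ from one another.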